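The compounds below may be only part of what the source reports. "The series", "measured", "known", "first", "only" and "open" are said of these compounds alone.

Measured so far in a functional assay on COLO 205 cells (Homo sapiens) for inhibition, read by sulforhodamine B assay, with a stated time of 48 h; a lower number here means that less compound is tolerated, a higher number that more compound is tolerated:
compound 1 `NS(=O)(=O)c1ccc(Nc2nc(N/N=C/c3ccc(C(F)(F)F)cc3)nc(Nc3ccccc3)n2)cc1` gives 10900 nM.
Compound 2 `Cc1nn(-c2ccccc2)cc1/C=N/Nc1nc(Nc2ccccc2)nc(Nc2ccc(S(N)(=O)=O)cc2)n1` gives only a limit of the assay, > 100000 nM.

Compound 2 thus stands at the upper edge of what this assay reports (the limit of > 100000 nM in this assay, at which 1 of the 2 values shown sits), with no number of its own. Compound 3 `NS(=O)(=O)c1ccc(Nc2nc(N/N=C/c3ccccn3)nc(Nc3ccccc3)n2)cc1` differs from compound 2 by pyridin-2-yl in place of 3-methyl-1-phenyl-1H-pyrazol-4-yl on a carbon with a double bond to nitrogen. Among the compounds with values here, one measured step concerns the same place: an at least 9.1-fold higher number from compound 1 to compound 2 (0.96 log units; beyond the scatter). Since the entering pyridin-2-yl is a six-membered aromatic ring, as was the group in compound 1, the number is expected to fall part of the way back. Compound 3 is therefore estimated at 30000 nM, between 8000 nM and 100000 nM. This expected step is an at least 3.3-fold lower number from compound 2 to compound 3 (0.52 log units; beyond the scatter), downward.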

Compound 3, concentration lethal to 50% of the cells: > 100000 nM
Compound 3: a limit, no number; the forecaster's own chance of this, stated with the estimate: 35%; at least 3.3-fold (0.52 log units) between middle value and limit.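

In this assay, a six-membered aromatic ring at this place is not enough to keep the number of compound 1: pyridin-2-yl in place of 4-(trifluoromethyl)phenyl gives an at least 9.1-fold higher number from compound 1 to compound 3 (0.96 log units; beyond the scatter). Compound 3 gives > 100000 nM, which is a limit of the assay and not a number. The step between compound 2 and compound 3 cannot be read, since both rest on the same limit: the limit of > 100000 nM in this assay, at which 2 of the 3 values shown sit.

From the compounds shown here alone, it remains open whether the trifluoromethyl group is what sets compound 1 apart. A plain phenyl or a 4-aminophenyl at this place could help to show that.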